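A few compounds are considered here, and "the series" means these few. Any claim that something is new, unique, unknown or untested is made for them only; others in the source may bear on it.

Measured compounds:
- compound 1, `Nc1ncnc2c1c(-c1cnc3[nH]ccc3c1)nn2CCCCCCC(=O)NO`: 19800 nM
- compound 2, `Nc1nc2cc(-c3nn(CCCCC(=O)NO)c4ncnc(N)c34)ccc2o1`: 14000 nM

Both compounds were tested in a functional assay on MCF7 cells (Homo sapiens) for inhibition, read by MTT assay, with a stated time of 72 h; on this read-out higher numbers stand for weaker inhibition and lower numbers for stronger inhibition. Compound 1 gives 19800 nM, the higher of the two numbers, and compound 2 gives 14000 nM; the gap between them lies within the usual scatter, so neither can be called the stronger inhibitor.

Compound 3, `Nc1ncnc2c1c(-c1cnc3[nH]ccc3c1)nn2CCC(=O)NO`, has not yet been measured. It differs from compound 1 in one place: hydroxycarbamoyl in place of 4-(hydroxycarbamoyl)butyl on a saturated chain carbon, two bonds along the chain from an aromatic nitrogen. The chain that carries the hydroxycarbamoyl group is thus much shorter, while the shared core is unchanged. Among the measured compounds shown here, no pair of measured compounds shows a change of this kind, so there is no measured step to rest on.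

The expectation for compound 3 is a move toward weaker inhibition, a step of a 2.3-fold higher number from compound 1 to compound 3 (0.36 log units; beyond the scatter) in this assay. Compound 3 is therefore estimated at 45000 nM, with a range from 14000 nM to 150000 nM.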

Compound 3, half-maximal inhibitory concentration: > 150000 nM
Compound 3: a limit, no number; the forecaster's own chance of this, stated with the estimate: 35%; at least 3.3-fold (0.52 log units) between middle value and limit.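

In this assay, this position on a saturated chain carbon, two bonds along the chain from an aromatic nitrogen, proves sensitive to chain length: hydroxycarbamoyl in place of 4-(hydroxycarbamoyl)butyl gives an at least 7.5-fold higher number from compound 1 to compound 3 (0.87 log units; beyond the scatter). Among the compounds shown here, this is the first view of a single change on the shared core, as compound 1 and compound 2 differ in more than one place and gave no measured step. The result for compound 3 is a limit and not a number, so the full size of the step cannot be read: the limit of > 150000 nM in this assay, at which 1 of the 3 values shown sits.

The compounds shown leave open how a chain of intermediate length on the shared core would read, and whether a chain longer than 5-(hydroxycarbamoyl)pentyl would give a lower number. They also leave open whether a carboxylic acid at the chain end could stand in for the hydroxycarbamoyl group.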